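The compounds below may be only part of what the source reports. "The series", "measured", "known", "first", "only" and "open" are said of these compounds alone.

Working notes on the series, read in an ADME assay on HEK-293T cells (Homo sapiens) for inhibition, read by CCK-8 assay, with a stated time of 48 h; a lower number here means a stronger inhibitor, a higher number a weaker inhibitor. Compound 1 (`COc1ccc(Cc2nnc(NC(=O)/C(C#N)=C/c3ccccc3OS(=O)(=O)c3ccc(OC)cc3)s2)cc1`) gives only a limit, > 50000 nM, and no number. Compound 2 (`COc1ccc(Cc2nnc(NC(=O)/C(C#N)=C/c3ccccc3OS(=O)(=O)c3ccc([N+](=O)[O-])cc3)s2)cc1`) also gives a limit, > 50000 nM. Compound 3 (`COc1ccc(Cc2nnc(NC(=O)/C(C#N)=C/c3ccccc3OS(=O)(=O)c3ccc(Cl)cc3)s2)cc1`) likewise gives a limit, > 50000 nM. The measured set therefore consists of the limit of > 50000 nM in this assay, at which 3 of the 3 values shown sit.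

Compound 4 (`COc1ccc(S(=O)(=O)Oc2ccccc2/C=C(\C#N)C(=O)Nc2nnc(Cc3ccc(Cl)cc3)s2)cc1`) is the next to be read. Its difference from compound 1 is chloro in place of methoxy on an aromatic carbon, which turns 4-methoxybenzyl into 4-chlorobenzyl. The closest measured change is a step that the two limits leave unreadable from compound 1 to compound 3, the same chloro in place of methoxy on an aromatic carbon, but made at the other methoxy of the molecule. The remaining steps, a step that the two limits leave unreadable from compound 1 to compound 2 and a step that the two limits leave unreadable from compound 2 to compound 3, have no readable size either. Among the compounds with values here, no measured step therefore supplies a size or a direction, and no shift beyond the scatter is expected in this assay. The expected step is a number no higher from compound 1 to compound 4 (the limit leaves the size open), and most likely the reading will again be only a limit. For compound 4 the estimated value is 50000 nM, with an expected range from 30000 nM to 100000 nM.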

Compound 4, half-maximal inhibitory concentration: > 50000 nM
Compound 4: only a limit was reported; the forecaster's own chance of this, stated with the estimate: 85%; the middle value sits exactly at the limit.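

The step between compound 1 and compound 4 cannot be read, since both stop at a limit in this assay: the limit of > 50000 nM in this assay, at which 4 of the 4 values shown sit.

The compounds shown leave open what size or direction, if any, the change from methoxy to chloro has on the half-maximal inhibitory concentration in this assay.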